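Swapping the Sulfonyl Aryl Group Toward Compound 4

The source may hold more compounds than are shown below. What is called first, only, known or untested is meant among the compounds shown, and "the series" means these compounds.

Compound 1 `Cc1ccc(S(=O)(=O)c2cnc3c(F)cccc3c2N2CCC(C)CC2)cc1`: 93%
Compound 2 `CC1CCN(c2c(S(=O)(=O)c3cc(F)cc(F)c3)cnc3c(F)cccc23)CC1`: 9%
Compound 3 `CC1CCN(c2c(S(=O)(=O)c3cc(F)cc(F)c3)cnc3cc(Cl)ccc23)CC1`: 94%

All three compounds were measured in an assay on isolated protein for displacement of a labelled ligand from metabotropic glutamate receptor 5 (Homo sapiens), with a stated time of 60 min, tested at 1 uM; on this read-out lower numbers stand for less inhibition and higher numbers for more inhibition at the one concentration tested (going by the name of the read-out). Compound 2 gives 9%, whereas compound 1 gives 93%. The change between them is 4-methylphenyl in place of 3,5-difluorophenyl on a sulfonyl sulfur, and the step is a number 84 percentage points higher from compound 2 to compound 1 (beyond the scatter). Compound 3, which carries a different core, gives 94%; its two values with compound 1 lie within the scatter of each other, while the difference between the cores of compound 2 and compound 3 is not broken down here.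

Compound 4 `Cc1ccc(S(=O)(=O)c2cnc3cc(Cl)ccc3c2N2CCC(C)CC2)cc1` has not yet been measured in this assay. It is related to compound 3 by 4-methylphenyl in place of 3,5-difluorophenyl on a sulfonyl sulfur, the same change seen from compound 2 to compound 1. The earlier step was large, but compound 3 already lies near the top of the read-out, so the step is expected to be small, a number 1 percentage points lower from compound 3 to compound 4 (within the scatter), because compound 3 gives 94%. Compound 4 is expected to give 93%, with a range from 80% to 99%.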

Compound 4, a percentage reported as inhibition, at one concentration (the size of the read-out at that concentration, not a potency): 94%
Compound 4: middle estimate off by 1 percentage points, on the low side, and the stated range covers the measured number.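

In this assay, the change to 4-methylphenyl in place of 3,5-difluorophenyl on a sulfonyl sulfur gives no change at the digits printed from compound 3 to compound 4 (within the scatter), and its size does not carry over from one core to the other: the same change on two cores in this assay, a number 84 percentage points higher (beyond the scatter) from compound 2 to compound 1 and no change at the digits printed (within the scatter) from compound 3 to compound 4, 84 percentage points apart, beyond the scatter of two such steps Within these two pairs, then, the outcome of this change depends on the core it is made on, so the large step seen on the core of compound 2 cannot be assumed on another core in this series. The result does not show which feature of the cores matters, and, as the read-out reports inhibition at one concentration only, compound 3 at 94% and compound 4 at 94% leave open how the two would compare at any other concentration.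

The compounds shown leave open how other groups on the sulfonyl sulfur would behave on either core, such as a phenyl carrying an amine or a carboxylic acid. They also leave open whether a longer chain in place of the methyl group on the saturated ring would keep the inhibition seen with compound 4.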